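Adding a hydroxy group to compound 3

A few compounds are considered here, and "the series" means these few. Any claim that something is new, unique, unknown or untested is made for them only; others in the source may bear on it.

Values from a functional assay on MCF7 cells (Homo sapiens) for cytotoxicity, read by MTT assay, with a stated time of 72 h (on this read-out lower numbers stand for stronger inhibition and higher numbers for weaker inhibition), follow.
Compound 1 `O=C(N/N=C/c1cccc(Br)c1)Nc1cc2c(Nc3ccc(F)c(Cl)c3)ncnc2cc1O[C@H]1CCOC1` gives 12400 nM
Compound 2 `O=C(N/N=C/c1ccc(O)cc1O)Nc1cc2c(Nc3ccc(F)c(Cl)c3)ncnc2cc1O[C@H]1CCOC1` gives 5350 nM
Compound 3 `COc1cc2ncnc(Nc3ccc(F)c(Cl)c3)c2cc1NC(=O)N/N=C/c1cccc(Br)c1` gives 27100 nM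

Compound 3 has the highest number of the three and therefore shows the weakest inhibition. The step of a 2.2-fold higher number from compound 1 to compound 3 (0.34 log units; beyond the scatter) comes with methyl in place of oxolan-3-yl on an oxygen on an aromatic ring. Compound 4 `COc1cc2ncnc(Nc3ccc(F)c(Cl)c3)c2cc1NC(=O)N/N=C/c1ccc(O)c(Br)c1` matches compound 3 except that 3-bromophenyl becomes 3-bromo-4-hydroxyphenyl. The counted change is hydroxy in place of hydrogen on an aromatic carbon and the hydroxy sits ortho to the bromo group and para to a large group.

The closest evidence is the step of a 2.3-fold lower number from compound 1 to compound 2 (0.37 log units; beyond the scatter), where 2,4-dihydroxyphenyl replaced 3-bromophenyl. It is modest, and it is only a rough guide, since compound 2 lacks the bromo group that compound 4 keeps. The step to compound 3 concerns another part of the molecule and does not bear directly on this change. Among the measured compounds shown here, no measured pair adds a hydroxy alone. A modest fall in the number is therefore expected in this assay, in the same direction as the step to compound 2. The expected size is a 1.8-fold lower number from compound 3 to compound 4 (0.26 log units; within the scatter), and it remains uncertain. For compound 4 the estimate is 15000 nM, with an expected range from 6000 nM to 32000 nM.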

Compound 4, half-maximal inhibitory concentration: "not active" (no number reported)
The entry for compound 4 holds no number; the estimate stays without a comparison.
By their numbers in this assay, from the lowest: compound 2; then compound 1; then compound 3.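

In this assay, among the compounds shown here, compound 4 is recorded as "not active" with no number, so no step from compound 3 to compound 4 can be read. The compounds shown leave open how far adding the hydroxy group moves compound 3 from 27100 nM on this read-out. No further data explain this result.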